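Three Flat Readings and a Fourth Compound Awaiting Measurement

The source may hold more compounds than are shown below. What is called first, only, known or untested is meant among the compounds shown, and "the series" means these compounds.

Measured so far:
compound 1, `Cc1csc(N)c1C(=O)c1ccc(Cl)cc1`: 1%
compound 2, `COc1ccc(-c2sc(N)c(C(=O)c3ccc(Cl)cc3)c2C)cc1`: 1%
compound 3, `CC(C)(C)Cc1c(-c2ccc(F)cc2F)sc(N)c1C(=O)c1ccc(Cl)cc1`: 1%

In an assay on CHO cells for displacement of a labelled ligand from adenosine receptor A3 (Homo sapiens), read by scintillation counting, tested at 10 uM (a higher number here means more inhibition at the concentration tested (going by the name of the read-out), a lower number less inhibition), compound 1 gives 1%. Among the compounds with values here, the one step between compounds that differ in a single place, no change at the digits printed from compound 1 to compound 2 (within the scatter), introduces a 4-methoxyphenyl in place of hydrogen on an aromatic carbon and leaves the read-out where it was. Compound 3 stands level with compounds 1 and 2 at the digits shown: in this assay compound 3 gives 1%, and against both neighbours the values show nothing beyond the scatter.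

Compound 4, `Cc1ccc(-c2sc(N)c(C(=O)c3ccc(Cl)cc3)c2CC(C)(C)C)cc1`, has not yet been measured. It differs from compound 3 in one place: 4-methylphenyl in place of 2,4-difluorophenyl on an aromatic carbon. Within the data shown here, the only measured step that bears on an aryl group at this position of the shared core is the one from compound 1 to compound 2, and it was flat. Since every measured compound sits at the same low level, the step from compound 3 to compound 4 in this assay is expected to be none beyond the scatter, a number 1 percentage points higher from compound 3 to compound 4 (within the scatter). For compound 4 in this assay the expected value is therefore 2%, within a range of -8% to 12%.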

Compound 4, a percentage reported as inhibition, at one concentration (the size of the read-out at that concentration, not a potency): 1%
Compound 4: middle estimate off by 1 percentage points, on the high side, within the range that was stated.
By their numbers in this assay, from the lowest: compounds 1, 2, 3 and 4 (each within the scatter of the next).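

In this assay, putting 4-methylphenyl in place of 2,4-difluorophenyl on the aromatic carbon next to the ring sulfur brought no change at the digits printed from compound 3 to compound 4 (within the scatter), with the neopentyl group and the rest of the compound left as they were. The earlier step at this position set an aryl group against hydrogen, whereas this one exchanges one substituted phenyl ring for another, so the fluorines leaving and the methyl entering are now seen to leave the reading unmoved as well. Nothing measured here accounts for this flat result.

All four compounds sit at the same low reading, so the series shows no gain to measure a loss against, and it cannot tell whether this position matters for the receptor at all. Open, as far as these compounds go, are a carboxylic acid or an amine on the phenyl ring at this position, a longer chain in place of the neopentyl group, and any replacement of the amino group or the (4-chlorophenyl)carbonyl group, both of which stay the same across these compounds.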